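A few compounds are considered here, and "the series" means these few. Any claim that something is new, unique, unknown or untested is made for them only; others in the source may bear on it.

Compound 1 `O=C1NC[C@@H](c2c[nH]c3ccccc23)N[C@H]1c1c[nH]c2ccccc12` is the unsubstituted parent of the pair. In an ADME assay on HCT-15 cells (Homo sapiens) for cytotoxicity (a higher number here means that more compound is needed for the effect, a lower number that less compound is needed), compound 1 gives only a limit, > 10 ug/mL. Compound 2 `O=C1NC[C@@H](c2c[nH]c3cc(Br)ccc23)N[C@H]1c1c[nH]c2ccccc12` carries bromo in place of hydrogen on an aromatic carbon, and in this assay compound 2 gives 6.3 ug/mL. Within the data shown here, the only measured step, an at least 1.5-fold lower number from compound 1 to compound 2 (0.20 log units; that floor lies within the scatter), has a floor that lies within the scatter because of the limit of > 10 ug/mL in this assay, at which 1 of the 2 values shown sits.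

Compound 3 `O=C1NC[C@@H](c2c[nH]c3ccccc23)N[C@H]1c1c[nH]c2cc(Br)ccc12` differs from compound 1 by bromo in place of hydrogen on an aromatic carbon, the same change placed on the other fused system. He expects a comparable step toward a lower number, an at least 1.5-fold lower number from compound 1 to compound 3 (0.18 log units; that floor lies within the scatter). Compound 3 is estimated at 6.5 ug/mL, within 3 ug/mL to 14 ug/mL.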

Compound 3, concentration for half-maximal effect: > 10 ug/mL
Compound 3 was reported as a limit (the forecaster's own chance of this, stated with the estimate: 25%); at least 1.5-fold (0.18 log units) between middle value and limit.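

Among these compounds, no step from compound 1 to compound 3 can be read in this assay, because both compounds give only a limit: the limit of > 10 ug/mL in this assay, at which 2 of the 3 values shown sit. The compounds shown leave open whether bromo in place of hydrogen at this place changes the number at all.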